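Sulfonyl aryl swap on the shared core: compound 3

The source may report more compounds than this note shows. Statements on the series, on what has been measured and on what is new or still open speak of the compounds shown alone.

Measured so far:
- compound 1 `CNCc1cn(S(=O)(=O)c2ccoc2)c(-c2cccnc2F)c1F` — a functional assay on the whole organism (strain Jcl:Sprague-Dawley) for inhibition, with Rattus norvegicus as the target, with stated times of 3 min and 3 h, at a dose of 1 mg/kg by the intravenous route; on this read-out higher numbers stand for more inhibition at the one dose given (going by the name of the read-out) and lower numbers for less inhibition: 95%
- compound 2 `CNCc1cn(S(=O)(=O)c2cccc(F)n2)c(-c2cccnc2F)c1F` — this assay: "not determined" (no result reported)

Compound 1 reaches a high level of inhibition in this assay. Compound 2 has no number in this assay, so nothing can be said of where it stands relative to compound 1; it serves here only as the structural reference for compound 3.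

Compound 3 `CNCc1cn(S(=O)(=O)c2ccc(C)nc2)c(-c2cccnc2F)c1F` differs from compound 2 in one place: 6-methylpyridin-3-yl in place of 6-fluoropyridin-2-yl on a sulfonyl sulfur. Both groups are six-membered aromatic rings with one hetero atom and one hydrogen-bond acceptor, attached to the same sulfonyl sulfur. Going by the values given here, no measured step exists for this change; in this assay a step of modest size is expected, in either direction, most likely within the usual scatter.

Compound 1 shows that a variant on the sulfonyl aryl can give 95%, and compound 3 is estimated at 85% (range 60% to 98%).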

Compound 3, a percentage reported as inhibition, in the whole organism at one dose (the size of the read-out at that dose, not a potency): 97%
For compound 3 the middle estimate is 12 percentage points below the measured one; low and high end bracket the measured number.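

In this assay, 6-methylpyridin-3-yl in place of furan-3-yl on a sulfonyl sulfur gives a number 2 percentage points higher from compound 1 to compound 3 (within the scatter). A high read-out at this position is therefore not confined to furan-3-yl, and the position accepts both of these aromatic rings on the shared core at this one dose. No data on hand explain why the two groups read alike.

Going by these compounds, the step from compound 2 to compound 3 cannot be read, so the effect of 6-fluoropyridin-2-yl at this position stays open, as does any separate contribution of the methyl group in compound 3. Also open, on these data alone, is whether inhibition holds with a sulfonyl substituent carrying an amine or a carboxylic acid, and with both compounds so high at one dose, the read-out gives no measure of potency.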